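This account rests on a few compounds, and the source may have more. Where it says the series, first, only, none or still open, it means among the compounds named here.

Measured in a functional assay on SW-620 cells (Homo sapiens); a lower number here means a stronger inhibitor, a higher number a weaker inhibitor:
Compound 1 `COc1cc(NC(C)CCCNC(=O)NCCO)c2ncccc2c1`: > 100000 nM (a limit)
Compound 2 `COc1cc(NC(C)CCCNC(=O)NCCCCCO)c2ncccc2c1`: 200 nM
Compound 3 `COC(=O)NCCCC(C)Nc1cc(OC)cc2cccnc12`: > 100000 nM (a limit)

Compound 3 stands at > 100000 nM, which is a limit of the assay and not a number. This limit is shared: the limit of > 100000 nM in this assay, at which 2 of the 3 values shown sit. Compound 4 `CCOC(=O)NCCCC(C)Nc1cc(OC)cc2cccnc12` carries one change, (methyl in place of hydrogen on a saturated chain carbon bound to an oxygen next to a carbonyl group), which turns methoxycarbonyl into ethoxycarbonyl. Two measured steps involve chains on the same carbonyl group: an at least 500-fold lower number from compound 1 to compound 2 (2.69 log units; beyond the scatter) and an at least 500-fold higher number from compound 2 to compound 3 (2.69 log units; beyond the scatter). Both are large, but both concern the hydroxy-bearing chains, and neither is this same change. In this assay, no step beyond the scatter is therefore expected, and no direction is favoured. The expected step is a number no higher from compound 3 to compound 4 (the limit leaves the size open). For compound 4 the estimate is 100000 nM, with an expected range from 30000 nM to 150000 nM.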

Compound 4, half-maximal inhibitory concentration: 45000 nM
The estimate for compound 4 lay 2.2-fold (0.35 log units) above the measured number, within the range that was stated.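

In this assay, a single methyl on this carbon brings the ethoxycarbonyl compound off the limit (an at least 2.2-fold lower number from compound 3 to compound 4 (0.34 log units; beyond the scatter)), and the same compound also reads apart from the (2-hydroxyethyl)amino compound (an at least 2.2-fold lower number from compound 1 to compound 4 (0.34 log units; beyond the scatter)). The starting point of that step is a limit, not a number, and it is a shared one: the limit of > 100000 nM in this assay, at which 2 of the 4 values shown sit. Even so, the gain is small beside what the (5-hydroxypentyl)amino chain gives (a 230-fold higher number from compound 2 to compound 4 (2.35 log units; beyond the scatter)). As far as these compounds go, whether a longer chain, such as propoxycarbonyl, would lower the number further stays open, as does the effect of an amine at the end of the ethyl group.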